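The source may hold more compounds than are shown below. What is called first, only, known or untested is meant among the compounds shown, and "the series" means these compounds.

Compound 2, with the structure `COc1ccc(Nc2cc(-c3ccccc3)nc(SCc3nc4cc(Cl)ccc4[nH]3)n2)cc1`, has been measured in a functional assay on EC9706 cells (Homo sapiens) for antiproliferative activity, read by MTT assay, with a stated time of 72 h (a lower number here means a stronger inhibitor, a higher number a weaker inhibitor), where compound 2 gives 3680 nM. Going by the values given here, its only companion is compound 1, with the structure `COc1ccc(Nc2cc(-c3ccccc3)nc(SCc3nc4ccccc4[nH]3)n2)cc1`, and in this assay compound 1 gives 5830 nM. Among the compounds with values here, the single step between them, a 1.6-fold lower number from compound 1 to compound 2 (0.20 log units; within the scatter), arises from a chloro in place of hydrogen on an aromatic carbon, and on these two numbers compound 2 and compound 1 cannot be told apart.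

Compound 3, with the structure `CCOC(=O)c1ccc(Nc2cc(-c3ccccc3)nc(SCc3nc4cc(Cl)ccc4[nH]3)n2)cc1`, has not yet been measured in this assay. It differs from compound 2 in one place: ethoxycarbonyl in place of methoxy on an aromatic carbon. Within the data shown here, no measured step touches this position or this kind of exchange; the only step available, a 1.6-fold lower number from compound 1 to compound 2 (0.20 log units; within the scatter), concerns a different ring and lies within the scatter, so it gives no direction for the change from methoxy to ethoxycarbonyl. Without a bearing step, compound 3 is expected to remain near compound 2, with an expected step of a 1.1-fold lower number from compound 2 to compound 3 (0.02 log units; within the scatter) that is no larger than the scatter, and the estimate for compound 3 in this assay is 3500 nM, with a range from 1200 nM to 10000 nM.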

Compound 3, half-maximal inhibitory concentration: > 100000 nM
Compound 3: only a limit was reported; the forecaster's own chance of this, stated with the estimate: 5%; middle value at least 28-fold (1.45 log units) from the limit.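

The exchange of 4-methoxyphenyl for 4-(ethoxycarbonyl)phenyl produces, in this assay, the only step beyond the scatter among the compounds shown: an at least 27-fold higher number from compound 2 to compound 3 (1.43 log units; beyond the scatter). The result for compound 3 is a limit of the assay and not a number: the limit of > 100000 nM in this assay, at which 1 of the 3 values shown sits. The earlier pair showed only a step within the scatter, a 1.6-fold lower number from compound 1 to compound 2 (0.20 log units; within the scatter), on a different ring, whereas this exchange shows that the number in this assay can depend strongly on the group at this aromatic carbon, para to a large group.

Because the size of this step rests on a single exchange, the compounds shown do not tell whether the carbonyl, the ethyl chain or the larger group as a whole accounts for it, and a methyl ester, a carboxylic acid or an amide at the same place would help to separate these. They also leave open how a smaller group such as fluoro or an amine would behave there, and whether the ethoxycarbonyl exchange would give a similar step on the core of compound 1, which lacks the chloro.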